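The source may report more compounds than this note shows. Statements on the series, on what has been measured and on what is new or still open speak of the compounds shown alone.

Compound 1 `COC(=O)[C@@]1(C)CCC=C2[C@@H]1CC[C@@H](C)[C@]2(C)Cc1c(C)[nH]c2ccc(Cl)cc12` and compound 2 `COC(=O)[C@@]1(C)CCC=C2[C@@H]1CC[C@@H](C)[C@]2(C)Cc1c(C)[nH]c2ccc(F)cc12` share one core, while compound 3 `COC(=O)[C@@]1(C)CC[C@@H]2C3=C1CC[C@@H](C)[C@]3(C)C[C@@H]1c3cc(Cl)ccc3N[C@H]21` and compound 4 `COC(=O)[C@@]1(C)CC[C@@H]2C3=C1CC[C@@H](C)[C@]3(C)C[C@@H]1c3cc(F)ccc3N[C@H]21` share another; the difference between the two cores is not broken down here. All were, or will be, tested in a functional assay on A549 cells (Homo sapiens) for inhibition, read by sulforhodamine B assay, with a stated time of 48 h; on this read-out higher numbers stand for weaker inhibition of growth and lower numbers for stronger inhibition of growth. In this assay compound 1 gives 17000 nM and compound 2 gives 15000 nM; the step of a 1.1-fold lower number from compound 1 to compound 2 (0.05 log units; within the scatter) comes from the change (fluoro in place of chloro on an aromatic carbon). Compound 3 gives 35000 nM in this assay, the highest of the three measured numbers. Compound 4 carries the same kind of change, (fluoro in place of chloro on an aromatic carbon), but here the aromatic ring that holds it is part of a fused or bridged system of five rings rather than of two rings, so the surroundings are not identical. Because the earlier step of a 1.1-fold lower number from compound 1 to compound 2 (0.05 log units; within the scatter) stayed within the scatter, the step of a 1.1-fold lower number from compound 3 to compound 4 (0.04 log units; within the scatter) is expected to be similarly small in this assay. Compound 4 is therefore estimated at 32000 nM in this assay, with a likely range from 15000 nM to 70000 nM.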

Compound 4, concentration for 50% growth inhibition: 25000 nM
The estimate for compound 4 lay 1.3-fold (0.11 log units) above the measured number; the range from low to high includes it.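

In this assay, fluoro in place of chloro on the second core gives a 1.4-fold lower number from compound 3 to compound 4 (0.15 log units; within the scatter), and set beside the earlier step, the two cores do not differ: the same change on two cores in this assay, a 1.1-fold lower number (0.05 log units; within the scatter) from compound 1 to compound 2 and a 1.4-fold lower number (0.15 log units; within the scatter) from compound 3 to compound 4, 1.2-fold (0.09 log units) apart, within the scatter of two such steps. In these two pairs, then, the small size of the step carries over from one core to the other, so the earlier pair was a fair guide to the later one. This does not show that the same would hold on a third core, and because both steps are within the scatter, it does not show how a larger step would carry between cores.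

The compounds shown leave open whether another group on that aromatic carbon, such as a methoxy group, an amine or a nitrile, would give a step beyond the scatter on either core. They also leave open what would happen if the methyl ester gave way to a carboxylic acid or an amide.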